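Stretching the alkyl chain on a shared core

The source may hold more compounds than are shown below. What is called first, only, known or untested is meant among the compounds shown, and "the series" means these compounds.

This account follows two measured compounds and one that is still to be measured, all built on the same core. Compound 1 `CCCCCc1ccc(-c2c(C)[nH]c(=O)n2C2CCCCC2)cc1` carries a pentyl chain on its aromatic ring, and in a functional assay on brain (Rattus norvegicus, strain Wistar) for inhibition (a higher number here means a weaker inhibitor, a lower number a stronger inhibitor), compound 1 gives 10600 nM. Compound 2 `CCCCCCc1ccc(-c2c(C)[nH]c(=O)n2C2CCCCC2)cc1` differs by methyl in place of hydrogen on a saturated chain carbon, five bonds along the chain from an aromatic carbon; in this assay compound 2 gives 13700 nM. Within the data shown here, the only measured step is a 1.3-fold higher number from compound 1 to compound 2 (0.11 log units; within the scatter), so the two numbers sit within the scatter of each other and neither can be placed above the other.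

Compound 3 `CCCCCCCCCCCCc1ccc(-c2c(C)[nH]c(=O)n2C2CCCCC2)cc1` is the unmeasured member. It differs from compound 2 by hexyl in place of hydrogen on a saturated chain carbon, six bonds along the chain from an aromatic carbon. Among the measured compounds shown here, the single step that bears on this change is the one from compound 1 to compound 2, and it was within the scatter. Adding hexyl goes much further than that step did, so no direction beyond the scatter is expected from the data at hand. The expected step is a 1.2-fold higher number from compound 2 to compound 3 (0.07 log units; within the scatter). Compound 3 is estimated at 16000 nM, with a range from 5000 nM to 50000 nM.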

Compound 3, half-maximal inhibitory concentration: > 100000 nM
Compound 3: only a limit was reported; the forecaster's own chance of this, stated with the estimate: 20%; at least 6.2-fold (0.79 log units) between middle value and limit.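

In this assay, this change shows that the chain is not as forgiving as the earlier pair suggested: a 1.3-fold higher number from compound 1 to compound 2 (0.11 log units; within the scatter) gave no readable shift, while hexyl in place of hydrogen on a saturated chain carbon, six bonds along the chain from an aromatic carbon, gives an at least 7.2-fold higher number from compound 2 to compound 3 (0.86 log units; beyond the scatter). Read from the pentyl chain of compound 1, the change is of the same kind, with an at least 9.4-fold higher number from compound 1 to compound 3 (0.97 log units; beyond the scatter), so both shorter chains now stand clearly apart from the long chain of compound 3. Compound 3 stands at a limit of the assay and not at a number: the limit of > 100000 nM in this assay, at which 1 of the 3 values shown sits.

From the compounds shown here alone, how far compound 3 lies past that limit stays open, and so does the point along the chain at which the number begins to climb. The compounds shown also do not tell whether an octyl or decyl chain, or a chain carrying a carboxylic acid or an amine, would stay near compound 2 or move as far as compound 3.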